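A few compounds are considered here, and "the series" means these few. Any claim that something is new, unique, unknown or untested is made for them only; others in the source may bear on it.

Compound 3 `Cc1c(C(=O)N/N=C\c2cccnc2)oc2cccc(O)c12` carries pyridin-3-yl on the carbon with a double bond to nitrogen. In a functional assay on PC-3 cells (Homo sapiens) for inhibition (on this read-out lower numbers stand for stronger inhibition and higher numbers for weaker inhibition), compound 3 gives >= 40000 nM, which is a limit of the assay and not a number. Compound 1 `Cc1c(C(=O)N/N=C\c2ccccc2F)oc2cccc(O)c12`, with 2-fluorophenyl at the same place, also returns a limit in this assay at >= 40000 nM. Among the compounds with values here, compound 2 `Cc1c(C(=O)N/N=C\c2cccc(O)c2O)oc2cccc(O)c12`, the 2,3-dihydroxyphenyl analogue, is the only member with a measured number, 12200 nM. The step from compound 1 to compound 2 is an at least 3.2-fold lower number from compound 1 to compound 2 (0.51 log units; beyond the scatter), and the step from compound 2 to compound 3 is an at least 3.2-fold higher number from compound 2 to compound 3 (0.51 log units; beyond the scatter); the step between compound 1 and compound 3 is a step that the two limits leave unreadable from compound 1 to compound 3, as both sit at the limit of >= 40000 nM in this assay, at which 2 of the 3 values shown sit. Compound 4 `COc1ccccc1/C=N\NC(=O)c1oc2cccc(O)c2c1C` is not yet measured; it changes compound 3 by 2-methoxyphenyl in place of pyridin-3-yl on a carbon with a double bond to nitrogen. The two readable steps show only that the 2,3-dihydroxyphenyl member stands apart while 2-fluorophenyl and pyridin-3-yl both run to the limit, and 2-methoxyphenyl lies nearer to the 2-fluorophenyl of compound 1 than to the 2,3-dihydroxyphenyl of compound 2. Compound 4 is therefore expected to stay at or near the limit, the expected step of a number no higher from compound 3 to compound 4 (the limit leaves the size open) not reaching beyond the scatter. The estimate for compound 4 is 40000 nM, between 15000 nM and 100000 nM, with a limit again the likelier outcome.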

Compound 4, half-maximal inhibitory concentration: 32700 nM
Compound 4: middle estimate off by 1.2-fold (0.09 log units), on the high side, and the stated range covers the measured number.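

In this assay, within the data shown here, compound 4 is the first member other than compound 2 to return a number and not a limit, yet the 2,3-dihydroxyphenyl member still stands apart: a 2.7-fold higher number from compound 2 to compound 4 (0.43 log units; beyond the scatter). Against the two limit members only floors can be read, an at least 1.2-fold lower number from compound 3 to compound 4 (0.08 log units; that floor lies within the scatter) and an at least 1.2-fold lower number from compound 1 to compound 4 (0.08 log units; that floor lies within the scatter), and both lie within the scatter, so neither 2-methoxyphenyl in place of pyridin-3-yl nor methoxy in place of fluoro on an aromatic carbon is shown to move the read-out. Compounds 1 and 3 remain limits of the assay and not numbers: the limit of >= 40000 nM in this assay, at which 2 of the 4 values shown sit.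

The compounds shown leave open whether the standing of compound 2 needs both hydroxy groups or only one, as a single hydroxyphenyl would test. Also open, going by these compounds, is how a phenyl ring carrying an amine or a carboxylic acid would read at this place.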